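This account rests on a few compounds, and the source may have more. Where it says the series, first, only, none or still open, it means among the compounds named here.

Among the measured compounds shown here, compound 2 `O=C(CSc1nnc(-c2ccncc2)o1)N/N=C/c1cc(Cl)ccc1O` gives 5830 nM in a functional assay on MCF7 cells (Homo sapiens) for cytotoxicity, read by MTT assay, with a stated time of 48 h (on this read-out higher numbers stand for weaker inhibition and lower numbers for stronger inhibition), and holds the higher of the two numbers so far, with compound 1 `O=C(CSc1nnc(-c2ccncc2)o1)N/N=C/c1ccccc1O` nearest at 4750 nM. For the measured compounds named here, the one measured step, a 1.2-fold higher number from compound 1 to compound 2 (0.09 log units; within the scatter), shows that adding a halogen here barely moved the read-out. Compound 3 `O=C(CSc1nnc(-c2ccncc2)o1)N/N=C/c1cc(Br)ccc1O` carries the change (bromo in place of chloro on an aromatic carbon). Going by the values given here, only the step to compound 2 bears on it, and that step lay within the scatter, so no shift beyond the scatter is expected in this assay. Compound 3 is therefore estimated at 5500 nM, ranging from 2500 nM to 12000 nM, an expected step of a 1.1-fold lower number from compound 2 to compound 3 (0.03 log units; within the scatter).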

Compound 3, half-maximal inhibitory concentration: 7770 nM
The estimate for compound 3 lay 1.4-fold (0.15 log units) below the measured number, within the range that was stated.
By their numbers in this assay, from the lowest: compounds 1, 2 and 3 (each within the scatter of the next).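

Bromo in place of chloro, para to a hydroxy group, gives a 1.3-fold higher number from compound 2 to compound 3 (0.12 log units; within the scatter) in this assay so the two halogens cannot be told apart at this position. Bromo in place of hydrogen gives a 1.6-fold higher number from compound 1 to compound 3 (0.21 log units; within the scatter) as well, so neither halogen yet stands clear of hydrogen here.

Still open, from the compounds shown here alone, is whether a group other than a halogen at this position, such as an amine, a methoxy group or a carboxylic acid, would move the number beyond the scatter. No supporting measurement is available to explain these small steps.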